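Adding a hydroxy group to compound 1

The source may report more compounds than this note shows. Statements on the series, on what has been measured and on what is new or still open speak of the compounds shown alone.

In a functional assay on HCT-116 cells (Homo sapiens) for inhibition, read by MTT assay, with a stated time of 48 h (a higher number here means a weaker inhibitor, a lower number a stronger inhibitor), compound 1 (`COc1cc(NCc2ccccc2)cc(OC)c1OC`) gives > 80000 nM as a limit of the assay and not a number. Two relatives do give measured numbers: compound 2 (`COc1ccc(CNc2cc(OC)c(OC)c(OC)c2)cc1[N+](=O)[O-]`) gives 18200 nM and compound 3 (`CCCCC(=O)N(Cc1ccc(OC)c(O)c1)c1cc(OC)c(OC)c(OC)c1`) gives 170 nM on the same scale. Each of them differs from compound 1 in more than one place, so neither shows what a single group does.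

Compound 4 (`COc1cc(NCc2cccc(O)c2)cc(OC)c1OC`) departs from compound 1 in one place only: hydroxy in place of hydrogen on an aromatic carbon (hydroxy in place of hydrogen on an aromatic carbon, phenyl to 3-hydroxyphenyl). Among the measured compounds shown here, no measured pair isolates this change, so any expectation is loose. Compound 3 at 170 nM also carries a hydroxy group, but it differs from compound 4 elsewhere as well. The nearer guide is compound 2 at 18200 nM and, like compound 4, it has no carbonyl. It suggests only a modest move toward a lower number in this assay and compound 4 may well stay at the limit. The expected change is an estimated at least 2.2-fold lower number from compound 1 to compound 4 (0.35 log units; beyond the scatter) and it remains a rough figure. The value expected for compound 4 is 35000 nM (estimated range 10000 nM to 80000 nM).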

Compound 4, half-maximal inhibitory concentration: 67700 nM
Estimate against measurement, compound 4: 1.9-fold (0.29 log units) below, and the stated range covers the measured number.
By their numbers in this assay, from the lowest: compound 3; then compound 2; then compound 4. At a limit, above all of these: compound 1.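

Hydroxy in place of hydrogen on an aromatic carbon, phenyl to 3-hydroxyphenyl, gives the first step in this set that isolates a single change, and it reads as an at least 1.1-fold lower number from compound 1 to compound 4 (0.07 log units; that floor lies within the scatter). Among the compounds shown here, with the hydroxy group at this place, meta to a large group, compound 4 gives a measured number in this assay, 67700 nM, which is a firmer reference point for this position than the earlier compounds offered. The value of compound 1 is a limit of the assay and not a number, and the step is only a floor for what this change does, because its starting point is not a measured number: the limit of > 80000 nM in this assay, at which 1 of the 4 values shown sits.

The compounds shown leave open whether an amine or a fluorine in place of the same hydrogen would differ from the hydroxy group, and whether the hydroxy group would give the same result on another carbon of that ring. For the compounds shown here, they also leave open what this single change does in a compound whose nitrogen carries a chain such as the one in compound 3.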